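From dichlorophenyl to dihydroxyphenyl on a shared core

The source may report more compounds than this note shows. Statements on the series, on what has been measured and on what is new or still open speak of the compounds shown alone.

In a functional assay on SW-620 cells (Homo sapiens) for cytotoxicity, read by MTT assay, with a stated time of 72 h (on this read-out lower numbers stand for stronger inhibition and higher numbers for weaker inhibition), compound 1 `COc1cccc(/C=C2\CCC/C(=C\c3ccc(Br)cc3)C2=O)c1OC` gives 11100 nM and compound 2 `COc1cccc(/C=C2\CCC/C(=C\c3ccc(Cl)c(Cl)c3)C2=O)c1OC` gives 10000 nM so the two stand within the scatter of each other. Compound 3 `COc1cccc(/C=C2\CCC/C(=C\c3ccc(O)c(O)c3)C2=O)c1OC` carries 3,4-dihydroxyphenyl in place of 3,4-dichlorophenyl on a double-bonded chain carbon bound to a double-bonded ring carbon on a double-bonded chain carbon bound to a double-bonded ring carbon. Among the measured compounds shown here, the only measured step, a 1.1-fold lower number from compound 1 to compound 2 (0.05 log units; within the scatter) exchanges one halogen-bearing phenyl for another and offers no direct evidence on hydroxyl groups, so only a modest move toward a lower number is expected. The estimated step is a 2.0-fold lower number from compound 2 to compound 3 (0.30 log units; within the scatter) and remains loosely held. In this assay compound 3 is expected at 5000 nM with an estimated range from 1500 nM to 15000 nM for now.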

Compound 3, half-maximal inhibitory concentration: 6300 nM
For compound 3 the middle estimate is 1.3-fold (0.10 log units) below the measured one; the measured number falls inside the stated range.
By their numbers in this assay, from the lowest: compounds 3, 2 and 1 (each within the scatter of the next).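

Until now this place on a double-bonded chain carbon held only halogen-bearing phenyl groups. 3,4-Dihydroxyphenyl brings hydrogen-bond donors and acceptors there, yet this assay records a 1.6-fold lower number from compound 2 to compound 3 (0.20 log units; within the scatter) and a 1.8-fold lower number from compound 1 to compound 3 (0.25 log units; within the scatter), so all three phenyl groups read alike here. No evidence is at hand that bears on this result. As far as these compounds go, whether an amine or a carboxylic acid on this phenyl ring would carry the number beyond the scatter stays open. So does the effect of changing the methoxy groups on the other side of the shared core.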